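The source may report more compounds than this note shows. Statements on the series, on what has been measured and on what is new or still open speak of the compounds shown alone.

In an assay on CHO cells for displacement of a labelled ligand from Substance-P receptor (Homo sapiens), in the presence of a further agent that is not named here (a higher number here means a weaker inhibitor, a lower number a stronger inhibitor), compound 3 `C[C@@H](O[C@H]1CN2C(=O)C=C(c3ccc[n+]([O-])c3)CC2[C@@H]1c1ccc(F)cc1)c1cc(C(F)(F)F)cc(C(F)(F)F)c1` shows the lowest number of the three measured here, giving 2.3 nM. Its nearest neighbour is compound 1 `C[C@@H](O[C@H]1CN2C(=O)C=C(c3ccc(C#N)cc3)CC2[C@@H]1c1ccc(F)cc1)c1cc(C(F)(F)F)cc(C(F)(F)F)c1`, which gives 53 nM; compound 2 `C[C@@H](O[C@H]1CN2C(=O)C=C(c3ccc(NS(C)(=O)=O)cc3)CC2[C@@H]1c1ccc(F)cc1)c1cc(C(F)(F)F)cc(C(F)(F)F)c1` gives 54 nM. Compound 4 `C[C@@H](O[C@H]1CN2C(=O)C=C(C3=CCOCC3)CC2[C@@H]1c1ccc(F)cc1)c1cc(C(F)(F)F)cc(C(F)(F)F)c1` differs from compound 3 in one place: a group of 6 heavy atoms (5 carbon, 1 oxygen; one six-membered non-aromatic ring with 1 hetero atom) in place of a group of 7 heavy atoms (5 carbon, 1 nitrogen, 1 oxygen; one six-membered aromatic ring with 1 hetero atom), on a double-bonded ring carbon. For the measured compounds named here, two measured steps bear on this position. Exchanging the all-carbon aromatic ring for the aromatic ring with one hetero atom gave a 23-fold lower number from compound 1 to compound 3 (1.36 log units; beyond the scatter) and a 23-fold lower number from compound 2 to compound 3 (1.37 log units; beyond the scatter), while the change between the two all-carbon rings, a 1.0-fold higher number from compound 1 to compound 2 (0.01 log units; within the scatter), stayed within the scatter. Going by the values given here, compound 4 carries a non-aromatic ring at this position, which no measured compound shows, so the direction is uncertain; the large gain seen on going to compound 3 is expected to be at least partly lost. The step from compound 3 to compound 4 is therefore expected to be an 11-fold higher number from compound 3 to compound 4 (1.04 log units; beyond the scatter), a higher number. For compound 4 the estimate in this assay is 25 nM, with a range from 6 nM to 110 nM.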

Compound 4, half-maximal inhibitory concentration: 9.6 nM
For compound 4 the middle estimate is 2.6-fold (0.42 log units) above the measured one; low and high end bracket the measured number.
By their numbers in this assay, from the lowest: compound 3; then compound 4; then compounds 1 and 2 (each within the scatter of the next).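

In this assay, the result shows that an aromatic ring is not needed at this double-bonded ring carbon for a number well under those of the all-carbon aromatic compounds: the six-membered non-aromatic ring with its hetero atom gives a 5.5-fold lower number from compound 1 to compound 4 (0.74 log units; beyond the scatter) and a 5.6-fold lower number from compound 2 to compound 4 (0.75 log units; beyond the scatter). The earlier compounds shown here showed only aromatic rings here, so they could not separate the effect of the aromatic ring with its hetero atom from that of other ring types. That aromatic ring still holds an edge, with a 4.2-fold higher number from compound 3 to compound 4 (0.62 log units; beyond the scatter), which places compound 4 between compound 3 and the pair of compounds 1 and 2.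

The compounds shown leave open how a plain pyridine ring or an all-carbon cyclohexenyl ring would compare at this position. Nothing available explains this ranking of the rings.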